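Aryloxy in place of oxanylamino: expected potency of compound 4

A few compounds are considered here, and "the series" means these few. Any claim that something is new, unique, unknown or untested is made for them only; others in the source may bear on it.

Compound 1 `Cc1cc(-c2cnn3c(NCC4CCOCC4)nc(NC4CCOCC4)nc23)ccc1C(=O)NC1CC1` is assessed in a functional assay on OVCAR-3 cells (Homo sapiens) for antiproliferative activity (a higher number here means a weaker inhibitor of growth, a lower number a stronger inhibitor of growth), where compound 1 gives 780 nM. Of the two numbers in this assay it is the lower one, but the gap to compound 3 `O=C(NC1CC1)c1ccc(-c2cnn3c(NCC4CCOCC4)nc(Oc4ccccc4)nc23)cc1`, which in this assay gives 910 nM, is within the scatter, so the two compounds cannot be ordered. Compound 2 `CC(C)C(=O)Nc1ccc(-c2cnn3c(NCC4CCOCC4)nc(OC4CCCC4)nc23)cc1` has no result in this assay, where compound 2 is recorded as "not determined" (no result reported). Compound 4 `CC(=O)Nc1cccc(Oc2nc(NCC3CCOCC3)n3ncc(-c4ccc(C(=O)NC5CC5)c(C)c4)c3n2)c1` differs from compound 1 in one place: 3-acetamidophenoxy in place of (oxan-4-yl)amino on an aromatic carbon. Going by the values given here, no pair of measured compounds differs only at this position, so no measured step is available for it. Compound 3 carries a phenoxy group at the same position of the shared core as compound 4, while also differing from compound 1 elsewhere, and its number sits within the scatter of compound 1; on the two compounds seen, an aryloxy group at this position appears tolerated. A step of a 1.0-fold lower number from compound 1 to compound 4 (0.02 log units; within the scatter) is therefore expected, none beyond the scatter in either direction. Compound 4 is estimated at 750 nM, with a range from 250 nM to 2500 nM.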

Compound 4, concentration for 50% growth inhibition: 1200 nM
Beside the measured number, compound 4's estimate is 1.6-fold (0.20 log units) below it; the measured number falls inside the stated range.
By their numbers in this assay, from the lowest: compounds 1, 3 and 4 (each within the scatter of the next).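

In this assay, going by these compounds alone, the change from (oxan-4-yl)amino to 3-acetamidophenoxy gives a 1.5-fold higher number from compound 1 to compound 4 (0.19 log units; within the scatter) and is the first measured step at this position of the shared core. The position, between two ring nitrogen atoms, thus accepts an entering group of 11 heavy atoms with an aromatic ring of carbon only in place of a leaving group of 7 heavy atoms with a non-aromatic ring, and the step stays within the scatter. No measurement on these compounds bears on the cause of this result.

As far as these compounds go, whether any group at this position moves growth inhibition beyond the scatter remains open. Also untested in the compounds shown is a one-place exchange of the acetamido group for a carboxylic acid or a piperazine, or of the ether oxygen for an amine nitrogen.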